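Trimethoxyphenyl pyrazole chalcones: amino to methoxy swap

The source may hold more compounds than are shown below. What is called first, only, known or untested is meant among the compounds shown, and "the series" means these compounds.

Notes on the series. Among the compounds with values here, compound 1 `COc1cc(-c2cc(/C=C/C(=O)c3ccc(N)cc3)[nH]n2)cc(OC)c1OC` gives -73% in a functional assay on HCT-116 cells (Homo sapiens) for cytotoxicity, read by sulforhodamine B assay, with a stated time of 48 h, tested at 100 uM (a lower number here means a stronger effect, a higher number a weaker effect of the compound at the concentration tested), and stands highest of the two numbers so far. Compound 2 `COc1ccc(-c2cc(/C=C/C(=O)c3ccc(N)cc3)[nH]n2)cc1OC` gives -89% in this assay; that step is a number 16 percentage points lower from compound 1 to compound 2 (beyond the scatter), a modest drop. Compound 3 `COc1ccc(C(=O)/C=C/c2cc(-c3cc(OC)c(OC)c(OC)c3)n[nH]2)cc1` differs from compound 1 by methoxy in place of amino on an aromatic carbon. Within the data shown here, this change is of a different kind from the single measured step, so no measured step bears on it directly. With no guidance on direction, a step of a number 5 percentage points higher from compound 1 to compound 3 (within the scatter) is expected, within the scatter. Compound 3 is therefore estimated at -68%, range -95% to -35%.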

Compound 3, a percentage reported as activity, at one concentration (the size of the read-out at that concentration, not a potency): -10%
Compound 3: middle estimate off by 58 percentage points, on the low side; the measured number lies above the stated range.
By their numbers in this assay, from the lowest: compound 2; then compound 1; then compound 3.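

With methoxy in place of amino on this aromatic carbon, para to a large group, this assay shows a number 63 percentage points higher from compound 1 to compound 3 (beyond the scatter), a much weaker effect at the concentration tested. Within the data shown here, the only earlier step lay elsewhere on the core and was modest, so this position is the more sensitive of the two places changed so far. Nothing at hand accounts for the loss.

Open, going by these compounds, is whether a hydroxy, dimethylamino or acetamido group at this place keeps the effect of compound 1. Also open, on these data alone, is whether the same change acts alike on the core of compound 2.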